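Aryl piperazine series in mice: from compound 2 to compound 3

The source may hold more compounds than are shown below. What is called first, only, known or untested is meant among the compounds shown, and "the series" means these compounds.

Measured so far:
- compound 1 `COc1ccccc1N1CCN(CCCOc2ccc3c(c2)CCC3)CC1` — 0%
- compound 2 `CC(=O)c1ccc(N2CCN(CCCOc3ccc4c(c3)CCC4)CC2)cc1` — 13%

Among the compounds with values here, in a functional assay on the whole organism for inhibition, with Mus musculus as the target, at a dose of 25 mg/kg by the oral route (on this read-out lower numbers stand for less inhibition and higher numbers for more inhibition at the one dose given (going by the name of the read-out)), compound 2 stands highest of the two numbers; the nearest is compound 1, and the only measured step is a number 13 percentage points higher from compound 1 to compound 2 (beyond the scatter), a modest change that lies beyond the scatter. Both compounds share the same core, and the only difference between them sits on the amine nitrogen of the six-membered ring.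

Compound 3 `O=[N+]([O-])c1ccccc1N1CCN(CCCOc2ccc3c(c2)CCC3)CC1` is not yet measured. It differs from compound 2 by 2-nitrophenyl in place of 4-acetylphenyl on an amine nitrogen in a ring. Within the data shown here, the one step that bears on this change is a number 13 percentage points higher from compound 1 to compound 2 (beyond the scatter), which shows that swapping the aryl group on that ring nitrogen can shift the read-out by a modest amount. Among the measured compounds shown here, no measured pair shows the 2-nitrophenyl group itself, so its effect is unknown; the two measured numbers are both low, and compound 1 sits at the floor. A step from compound 2 to compound 3 of about the same size as the measured one, in the downward direction, or no step beyond the scatter, is the expectation. Compound 3 is estimated at 6%, with a range from 0% to 20%. The expected step is a number 7 percentage points lower from compound 2 to compound 3 (within the scatter).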

Compound 3, a percentage reported as inhibition, in the whole organism at one dose (the size of the read-out at that dose, not a potency): 8%
The estimate for compound 3 lay 2 percentage points below the measured number; measured number inside the range.
By their numbers in this assay, from the lowest: compounds 1, 3 and 2 (each within the scatter of the next, the first and the last beyond it).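

In this assay the 2-nitrophenyl group on the amine nitrogen in the ring does not separate from either of the other two aryl groups: the read-out shows a number 5 percentage points lower from compound 2 to compound 3 (within the scatter) and a number 8 percentage points higher from compound 1 to compound 3 (within the scatter) as the two new steps. Within the data shown here, the only step beyond the scatter remains a number 13 percentage points higher from compound 1 to compound 2 (beyond the scatter) and compound 3 lies within the scatter of both its ends, so these three compounds give one separated pair and no graded order at this position. Taken alone, nitro in place of methoxy on the aromatic carbon leaves the read-out unresolved, and no measurement here bears on why the numbers fall as they do.

Open, as far as these compounds go, is whether 4-nitrophenyl or 2-acetylphenyl on the same nitrogen would tell the effect of the group from the effect of its place on the aryl ring, as compound 2 and compound 3 differ in both. Also open, from the compounds shown here alone, is whether a plain phenyl, a pyridine ring or a carboxylic acid on the aryl ring would lift the read-out clearly above this low band in this assay at the one dose given.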